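Fluorine placement on the benzyl group

This account rests on a few compounds, and the source may have more. Where it says the series, first, only, none or still open, it means among the compounds named here.

Going by the values given here, compound 2 `CC1(C)c2[nH]nc(NC(=O)c3ccccc3)c2CN1Cc1cc(F)cc(F)c1` gives 190 nM in an assay on Sf21 cells for inhibition of high affinity nerve growth factor receptor (Homo sapiens), read by HTRF, with a stated time of 30 min, in the presence of a further agent that is not named here (a higher number here means a weaker inhibitor, a lower number a stronger inhibitor), the lowest of the two numbers so far; compound 1 `CC1(C)c2[nH]nc(NC(=O)c3ccccc3)c2CN1Cc1cccc(C#N)c1` gives 980 nM. Among the compounds with values here, the single measured step, a 5.2-fold lower number from compound 1 to compound 2 (0.71 log units; beyond the scatter), concerns exchanging the whole substituent pattern rather than moving a fluorine. Compound 3 `CC1(C)c2[nH]nc(NC(=O)c3ccccc3)c2CN1Cc1cc(F)ccc1F` differs from compound 2 by 2,5-difluorophenyl in place of 3,5-difluorophenyl on a saturated chain carbon bound to an amine nitrogen in a ring. Within the data shown here, no measured step addresses this kind of change, so the expectation rests on compound 2 alone, and only a small step, within the scatter, is expected: a 1.6-fold higher number from compound 2 to compound 3 (0.20 log units; within the scatter). Compound 3 is expected to give 300 nM in this assay, within a range of 110 nM to 850 nM.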

Compound 3, half-maximal inhibitory concentration: 480 nM
For compound 3 the middle estimate is 1.6-fold (0.20 log units) below the measured one; measured number inside the range.
By their numbers in this assay, from the lowest: compound 2; then compound 3; then compound 1.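

Moving one fluorine on the benzyl group, with the atoms unchanged, already registers in this assay (a 2.5-fold higher number from compound 2 to compound 3 (0.40 log units; beyond the scatter)), so the change from 3,5-difluorobenzyl to 2,5-difluorobenzyl is not neutral at this position. The 2,5-difluorophenyl group still gives a lower number than 3-cyanophenyl (a 2.0-fold lower number from compound 1 to compound 3 (0.31 log units; beyond the scatter)), placing compound 3 between the other two. No evidence on hand bears on this difference between the two fluorine patterns.

From the compounds shown here alone, how an unsubstituted phenyl, a single fluorine or a methoxy group compares at this place remains open. So does whether the effect of fluorine placement persists when the benzoyl group of the shared core is changed.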